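The compounds below may be only part of what the source reports. "The series", "measured", "known", "first", "only" and "open" are said of these compounds alone.

Compounds measured so far:
Compound 1, `CCCCCSc1nnc(COc2cc(C)c3c(C)cc(=O)oc3c2)o1`. In a functional assay on MDA-MB-231 cells (Homo sapiens) for antiproliferative activity, read by MTT assay, with a stated time of 24 h (on this read-out higher numbers stand for weaker inhibition and lower numbers for stronger inhibition), compound 1 gives > 100000 nM, which is a limit of the assay rather than a number.
Compound 2, `CCCCCCSc1nnc(COc2cc(C)c3c(C)cc(=O)oc3c2)o1`. In this assay compound 2 gives > 100000 nM, likewise a limit.
Compound 3, `Cc1cc(OCc2nnc(SCc3ccccc3)o2)cc2oc(=O)cc(C)c12`. In this assay compound 3 gives > 100000 nM, again a limit.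

Compound 3 therefore stands where every measured compound stands, at the limit of > 100000 nM in this assay, at which 3 of the 3 values shown sit. The steps among them, a step that the two limits leave unreadable from compound 1 to compound 2, a step that the two limits leave unreadable from compound 1 to compound 3 and a step that the two limits leave unreadable from compound 2 to compound 3, carry no readable size. Each of them joins two limits.

Compound 4, `Cc1cc(OCc2nnc(SCc3ccc(Cl)cc3Cl)o2)cc2oc(=O)cc(C)c12`, differs from compound 3 by 2,4-dichlorophenyl in place of phenyl on a saturated chain carbon bound to a sulfur. Among the measured compounds shown here, none of the measured steps exchanges one aryl group for another at that carbon; the nearest, a step that the two limits leave unreadable from compound 1 to compound 3 and a step that the two limits leave unreadable from compound 2 to compound 3, put an aryl group in place of a chain there and remain unreadable. The measured steps thus give neither a direction nor a size for the change to compound 4. The expectation is that compound 4 also falls at the limit, so the estimated step of a number no higher from compound 3 to compound 4 (the limit leaves the size open) is taken as no change beyond the scatter. Compound 4 is accordingly expected at 100000 nM, within a range from 30000 nM to 300000 nM, with a strong chance that only a limit is reported.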

Compound 4, half-maximal inhibitory concentration: > 100000 nM
Compound 4 gave a limit, no number; the forecaster's own chance of this, stated with the estimate: 80%; the middle value lies on the limit itself.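

Compound 4, like compound 1, compound 2 and compound 3, gives only a limit in this assay, so none of the steps joining compound 4 to those three can be read: the limit of > 100000 nM in this assay, at which 4 of the 4 values shown sit.

The compounds shown leave open whether any group on the saturated chain carbon bound to a sulfur gives a readable value in this assay.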